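This account rests on a few compounds, and the source may have more. Where it says the series, first, only, none or still open, it means among the compounds named here.

Within the data shown here, in a physicochemical assay for solubility, read by mass spectrometry, in phosphate buffer, with a stated time of 24 h, at pH 7.4 (a higher number here means a more soluble compound, a lower number a less soluble compound), three compounds have numbers so far. Compound 2 `Cc1ccoc1C(=O)N1CCC(NC(=O)Nc2ccc(C(F)(F)F)cc2)CC1` gives 0.8 ug/mL and sits at the low end of the three, level with compound 3 `Cc1ccoc1C(=O)N1CCC(NC(=O)Nc2ccc(OC(F)(F)F)cc2)CC1` at 0.92 ug/mL within the usual scatter. Compound 1 `O=C(Nc1ccc(OC(F)(F)F)c(F)c1)NC1CCN(C(=O)C2(C(F)(F)F)CC2)CC1` stands far higher at 92 ug/mL but differs from compound 2 in more than one place, so that gap cannot be tied to any single change.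

Compound 4 `O=C(Nc1ccc(C(F)(F)F)cc1)NC1CCN(C(=O)c2ccoc2)CC1` has not been measured yet. It differs from compound 2 in one place, where furan-3-yl stands in place of 3-methylfuran-2-yl on a carbonyl carbon (furan-3-yl in place of 3-methylfuran-2-yl on a carbonyl carbon).

Among the measured compounds shown here, no measured step covers this change. The nearest guide is a 1.2-fold higher number from compound 2 to compound 3 (0.06 log units; within the scatter) (trifluoromethoxy in place of trifluoromethyl on an aromatic carbon), which lies within the scatter but concerns a different place in the molecule, so it says little about this one. For the measured compounds named here, with only that small step to go on, no step beyond the scatter is expected in this assay and the range is left wide. The expected step is a 1.5-fold higher number from compound 2 to compound 4 (0.18 log units; within the scatter) and it stays within the scatter. For compound 4 the estimate is 1.2 ug/mL with an expected range from 0.4 ug/mL to 5 ug/mL.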

Compound 4, solubility: 2.2 ug/mL
Beside the measured number, compound 4's estimate is 1.8-fold (0.26 log units) below it; the measured number falls inside the stated range.
By their numbers in this assay, from the lowest: compounds 2 and 3 (each within the scatter of the next); then compound 4; then compound 1.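

Among these compounds, this is the first measured change at the carbonyl carbon: in this assay, furan-3-yl in place of 3-methylfuran-2-yl gives a 2.8-fold higher number from compound 2 to compound 4 (0.44 log units; beyond the scatter), a modest step but one beyond the scatter, whereas the change on the aromatic carbon gave only a 1.2-fold higher number from compound 2 to compound 3 (0.06 log units; within the scatter), within the scatter. Of the two single-place changes shown, then, only the one at the carbonyl carbon moves the number measurably, although this change alters two things at once: the methyl group is lost and the furan is named as a 3-yl rather than a 2-yl group, so this one step cannot divide its size between them. Nothing available explains why this swap raises the number.

As far as these compounds go, it remains open whether furan-2-yl without the methyl would fall with compound 2 or with compound 4, a comparison that would separate those two parts of the change. Also open, from the compounds shown here alone, is what a pyridine ring or a group carrying an amine would do on the same carbonyl carbon, and whether the step would repeat with trifluoromethoxy on the aromatic carbon, as in compound 3.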